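The source may hold more compounds than are shown below. What is called first, only, known or untested is meant among the compounds shown, and "the series" means these compounds.

Four compounds from this study share one core and differ at two sites. Compound 1 `CCN(CC)C/C=C/C(=O)Nc1cc2c(N3CCc4ccccc43)ncnc2cc1OC` carries a diethylamino group on a saturated chain carbon bound to a double-bonded chain carbon, together with a methoxy group on an oxygen on an aromatic ring. In a functional assay on A549 cells (Homo sapiens) for antiproliferative activity, read by MTT assay, with a stated time of 72 h (on this read-out higher numbers stand for weaker inhibition and lower numbers for stronger inhibition), compound 1 gives 1690 nM. Compound 2 `COc1cc2ncnc(N3CCc4ccccc43)c2cc1NC(=O)/C=C/CN1CCCC1` differs from it by pyrrolidin-1-yl in place of diethylamino on a saturated chain carbon bound to a double-bonded chain carbon and in this assay compound 2 gives 1210 nM; the resulting step is a 1.4-fold lower number from compound 1 to compound 2 (0.15 log units; within the scatter).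

Compound 3 `CCN(CC)C/C=C/C(=O)Nc1cc2c(N3CCc4ccccc43)ncnc2cc1O[C@@H]1CCOC1` keeps the diethylamino group but differs from compound 1 by oxolan-3-yl in place of methyl on an oxygen on an aromatic ring. In this assay compound 3 gives 5220 nM, and the step from the methyl compound is a 3.1-fold higher number from compound 1 to compound 3 (0.49 log units; beyond the scatter). Among the three measured compounds, compound 3 therefore gives the highest number, standing beyond the scatter from both others.

Compound 4 `O=C(/C=C/CN1CCCC1)Nc1cc2c(N3CCc4ccccc43)ncnc2cc1O[C@@H]1CCOC1` has not yet been measured in this assay. It differs from compound 3 by pyrrolidin-1-yl in place of diethylamino on a saturated chain carbon bound to a double-bonded chain carbon. Among the compounds with values here, this is the same change, at the same place, as the one that separates compound 1 from compound 2, where the step was a 1.4-fold lower number from compound 1 to compound 2 (0.15 log units; within the scatter). Within the data shown here, the core of compound 3 differs from that of compound 1 by oxolan-3-yl in place of methyl on an oxygen on an aromatic ring, so only one earlier instance of this change is available. Resting on that single step and on the value of compound 3, 5220 nM, the expected step from compound 3 to compound 4 is a 1.3-fold lower number from compound 3 to compound 4 (0.13 log units; within the scatter). Compound 4 is estimated to give 3900 nM in this assay, with a likely range from 1800 nM to 8500 nM.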

Compound 4, half-maximal inhibitory concentration: 2230 nM
Compound 4: the middle estimate sits 1.7-fold (0.24 log units) above what was measured; measured number inside the range.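

Replacing diethylamino with pyrrolidin-1-yl on the core of compound 3 gives a 2.3-fold lower number from compound 3 to compound 4 (0.37 log units; beyond the scatter) in this assay, and this step cannot be told apart from the earlier one on the core of compound 1: the same change on two cores in this assay, a 1.4-fold lower number (0.15 log units; within the scatter) from compound 1 to compound 2 and a 2.3-fold lower number (0.37 log units; beyond the scatter) from compound 3 to compound 4, 1.7-fold (0.22 log units) apart, within the scatter of two such steps. Read on the pyrrolidin-1-yl compounds, oxolan-3-yl in place of methyl on the oxygen gives a 1.8-fold higher number from compound 2 to compound 4 (0.27 log units; within the scatter), and this step likewise cannot be told apart from its earlier counterpart: the same change on two cores in this assay, a 3.1-fold higher number (0.49 log units; beyond the scatter) from compound 1 to compound 3 and a 1.8-fold higher number (0.27 log units; within the scatter) from compound 2 to compound 4, 1.7-fold (0.22 log units) apart, within the scatter of two such steps. Each change therefore carried over between these two cores without a detectable difference in size, but this rests on only four compounds, and because one step in each pair lies within the scatter, it does not establish a firm effect for either change on both cores or a rule for the wider series.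

The compounds shown leave open whether the same carry-over would hold for other amines on the chain, such as dimethylamino, piperidin-1-yl or morpholin-4-yl. They also leave open how other groups on the oxygen, such as ethyl or oxan-4-yl, or the opposite mirror form of oxolan-3-yl, would behave on these two cores.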